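This account rests on a few compounds, and the source may have more. Where it says the series, first, only, none or still open, it means among the compounds named here.

Compound 1 `CS(=O)(=O)/C(C#N)=C/c1c[nH]c2ccccc12` carries a methyl group on its sulfonyl sulfur. In a functional assay on MT4 cells (Homo sapiens) for antiproliferative activity, read by MTT assay, with a stated time of 96 h (on this read-out higher numbers stand for an effect only at larger amounts of compound and lower numbers for an effect already at smaller amounts), compound 1 gives only > 100000 nM, which is a limit of the assay and not a number. Compound 2 `N#C/C(=C\c1c[nH]c2ccccc12)S(=O)(=O)c1ccccc1` differs from it by a phenyl in place of the methyl on the sulfonyl sulfur; in this assay compound 2 also gives only > 100000 nM, again a limit rather than a number. The step that the two limits leave unreadable from compound 1 to compound 2 therefore cannot be read, because of the limit of > 100000 nM in this assay, at which 2 of the 3 values shown sit. Compound 3 `Cc1ccc(S(=O)(=O)/C(C#N)=C/c2c(-c3ccccc3)[nH]c3ccccc23)cc1` differs from both in more than one place, and in this assay compound 3 gives 400 nM.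

Compound 4 `Cc1[nH]c2ccccc2c1/C=C(\C#N)S(C)(=O)=O` is the compound still to be measured. It differs from compound 1 only by methyl in place of hydrogen on an aromatic carbon. Among the compounds with values here, none of the measured steps changes this position, so no step bears directly on it, and the only readable value, that of compound 3, comes from a compound that also differs elsewhere. Compound 4 is therefore expected to sit close to compound 1, most likely again at a limit, with an expected step of an at least 1.2-fold lower number from compound 1 to compound 4 (0.09 log units; that floor lies within the scatter). The estimate for compound 4 in this assay is 80000 nM, within 10000 nM to 300000 nM.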

Compound 4, half-maximal effective concentration: > 100000 nM
Compound 4: no number, only a limit (the forecaster's own chance of this, stated with the estimate: 60%); middle value at least 1.2-fold (0.09 log units) from the limit.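

Compound 1 and compound 4 both stop at a limit of this assay and not at a number, so no step between them can be read: the limit of > 100000 nM in this assay, at which 3 of the 4 values shown sit.

The compounds shown leave open what methyl in place of hydrogen on an aromatic carbon does to the effect, and which of the several differences of compound 3 goes with its readable value.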